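A Chlorophenyl Swap on a Shared Core

The compounds below may be only part of what the source reports. "The series", "measured", "known", "first", "only" and "open" are said of these compounds alone.

Compound 1 `COc1ccccc1-c1ncnn1-c1cc(OC)c(OC)c(OC)c1` gives a limit of > 10000 nM in a functional assay on HL-60 cells (Homo sapiens) for antiproliferative activity, read by MTT assay, with a stated time of 72 h; on this read-out lower numbers stand for stronger inhibition and higher numbers for weaker inhibition. Compound 2 `COc1cc(-c2ncnn2-c2ccc(Cl)c(Cl)c2)cc(OC)c1OC` gives a limit of > 10000 nM. Compound 3 `CCOc1ccccc1-c1ncnn1-c1cc(OC)c(OC)c(OC)c1` gives a limit of > 10000 nM.

Compound 1 therefore stands only at the assay limit, where all three measured compounds sit (the limit of > 10000 nM in this assay, at which 3 of the 3 values shown sit). Among the measured compounds shown here, the only one-place step measured, a step that the two limits leave unreadable from compound 1 to compound 3, has a limit at both ends and so its size cannot be read. Compound 4 `COc1cc(-n2ncnc2-c2cccc(Cl)c2)cc(OC)c1OC` differs from compound 1 by 3-chlorophenyl in place of 2-methoxyphenyl on an aromatic carbon. For the measured compounds named here, no measured step bears on this change, so nothing here points to a gain beyond the scatter. Compound 4 is expected to come out at 15000 nM, with a range from 3000 nM to 60000 nM, which would be an estimated step that the limit leaves unreadable from compound 1 to compound 4.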

Compound 4, half-maximal inhibitory concentration: > 10000 nM
Compound 4 was reported as a limit; the forecaster's own chance of this, stated with the estimate: 65%; the middle value does not contradict the limit.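

In this assay compound 1 and compound 4 both stand at a limit, so no size can be read for the step between them: the limit of > 10000 nM in this assay, at which 4 of the 4 values shown sit.

Which change to the shared core would give a measurable value stays open.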